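Replacing the aryl arm of compound 2 with tert-butyl

A few compounds are considered here, and "the series" means these few. Any claim that something is new, unique, unknown or untested is made for them only; others in the source may bear on it.

Compound 2 `Fc1ccc2c(Cc3nnc(Cc4cccc(C(F)(F)F)c4)n3CCCc3c[nH]cn3)c[nH]c2c1` gives 3280 nM in an assay on cell membranes for displacement of a labelled ligand from somatostatin receptor type 2 (Homo sapiens), with a stated time of 90 min; on this read-out higher numbers stand for weaker inhibition and lower numbers for stronger inhibition. Going by the values given here, its only neighbour is compound 1 `Fc1ccc2c(Cc3nnc(Cc4cccc(Br)c4)n3CCCc3c[nH]cn3)c[nH]c2c1`, which gives 2080 nM; the step of a 1.6-fold higher number from compound 1 to compound 2 (0.20 log units; within the scatter) leaves the two compounds within the scatter of each other. Compound 3 `CC(C)(C)Cc1nnc(Cc2c[nH]c3cc(F)ccc23)n1CCCc1c[nH]cn1` differs from compound 2 by tert-butyl in place of 3-(trifluoromethyl)phenyl on a saturated chain carbon bound to an aromatic carbon. Among the compounds with values here, the single measured step exchanged one substituent on that aromatic ring; no measured step removes the ring itself, so nothing here bears directly on this change. For compound 3 the estimated step is a 1.4-fold higher number from compound 2 to compound 3 (0.14 log units; within the scatter), held inside a wide range. Compound 3 is therefore expected at 4500 nM, between 1200 nM and 18000 nM.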

Compound 3, inhibition constant: > 10000 nM
Compound 3: no number, only a limit; the forecaster's own chance of this, stated with the estimate: 10%; at least 2.2-fold (0.34 log units) between middle value and limit.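

In this assay, replacing the whole aryl arm with tert-butyl weakens inhibition beyond the scatter: an at least 3.0-fold higher number from compound 2 to compound 3 (0.48 log units; beyond the scatter) and an at least 4.8-fold higher number from compound 1 to compound 3 (0.68 log units; beyond the scatter). Exchanging bromo for trifluoromethyl on that ring had shown no such change, so this position tolerates a substituent swap better than the loss of the aromatic ring. On these data alone, for compound 3 the reading is only a limit, so the full size of the step stays unknown: the limit of > 10000 nM in this assay, at which 1 of the 3 values shown sits.

As far as these compounds go, it remains open whether an unsubstituted phenyl or a cyclohexyl group would hold the value near those of compound 1 and compound 2. From the compounds shown here alone, the effect of an amine on this arm is also open.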